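The source may hold more compounds than are shown below. What is called first, only, known or untested is meant among the compounds shown, and "the series" means these compounds.

Compound 1 `COc1cc(OC)cc(C(=O)Nc2cccc(-c3oc4cc(-c5ccc(F)cc5)ccc4c(=O)c3O)c2)c1` carries a 3,5-dimethoxyphenyl on the carbonyl carbon of its amide; in a functional assay on HCC1937 cells (Homo sapiens) for antiproliferative activity, read by CCK-8 assay, with a stated time of 72 h (on this read-out lower numbers stand for stronger inhibition and higher numbers for weaker inhibition), compound 1 gives 6250 nM. Compound 2 `Cc1cc(C)cc(C(=O)Nc2cccc(-c3oc4cc(-c5ccc(F)cc5)ccc4c(=O)c3O)c2)c1` differs only in that ring, and in this assay compound 2 gives 4860 nM. Going by the values given here, the change between them, a 1.3-fold lower number from compound 1 to compound 2 (0.11 log units; within the scatter), lies within the scatter, so the two numbers cannot be told apart, and compound 2 stands with compound 1 as the only pair of measured values here.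

Compound 3 `CCCc1ccc(C(=O)Nc2cccc(-c3oc4cc(-c5ccc(F)cc5)ccc4c(=O)c3O)c2)cc1` continues the series at the same place: 4-propylphenyl in place of 3,5-dimethylphenyl on a carbonyl carbon. Among the compounds with values here, the one measured step that bears on it, a 1.3-fold lower number from compound 1 to compound 2 (0.11 log units; within the scatter), also exchanged the ring on that carbonyl carbon and produced no change beyond the scatter. On that basis a step of similar size is expected, with no clear direction, and compound 3 is estimated to give an expected step of a 1.0-fold higher number from compound 2 to compound 3 (0.01 log units; within the scatter) in this assay. For compound 3 the estimate in this assay is 5000 nM, with a range from 2000 nM to 12000 nM.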

Compound 3, half-maximal inhibitory concentration: 15400 nM
The estimate for compound 3 lay 3.1-fold (0.49 log units) below the measured number, outside the stated range (above it).
By their numbers in this assay, from the lowest: compounds 2 and 1 (each within the scatter of the next); then compound 3.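

In this assay, the ring on the carbonyl carbon of the amide is no longer a place where exchanges pass without effect: 4-propylphenyl in place of 3,5-dimethylphenyl gives a 3.2-fold higher number from compound 2 to compound 3 (0.50 log units; beyond the scatter), and in place of 3,5-dimethoxyphenyl it gives a 2.5-fold higher number from compound 1 to compound 3 (0.39 log units; beyond the scatter), both beyond the scatter, though modest. The exchange between 3,5-dimethoxyphenyl and 3,5-dimethylphenyl had shown no such step, so this position does respond to the ring it carries, and compound 3 stands apart from compound 1 and compound 2, which remain within the scatter of each other. The data offer nothing that accounts for this step.

The compounds shown leave open whether the higher number follows the propyl chain itself or the change in the ring's substitution pattern, since 4-propylphenyl differs from both other rings in both respects. They also leave open how this position would respond to a methyl or an ethyl in place of the propyl chain, or to an amine or a carboxylic acid on the ring.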